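This account rests on a few compounds, and the source may have more. Where it says the series, first, only, none or still open, it means among the compounds named here.

Measured so far in an ADME assay on HEK-293T cells (Homo sapiens) for cytotoxicity, read by MTT assay, with a stated time of 3 days; a lower number here means that less compound is tolerated, a higher number that more compound is tolerated:
Compound 1 `CC(=O)Oc1ccccc1CN(C(=O)COC(=O)c1ccc([N+](=O)[O-])o1)C(C)(C)C`: > 100000 nM
Compound 2 `COc1ccc(CN(C(=O)COC(=O)c2ccc([N+](=O)[O-])o2)C(C)(C)C)cc1`: > 100000 nM
Compound 3 `CC(C)(C)N(Cc1ccc(F)cc1)C(=O)COC(=O)c1ccc([N+](=O)[O-])o1`: > 100000 nM

Each of these entries is a limit of the assay and not a number. Compound 3 stands at > 100000 nM, which is a limit. It has no place of its own within the set, and the three compounds share one reading: the limit of > 100000 nM in this assay, at which 3 of the 3 values shown sit.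

Compound 4 `CC(C)(C)N(Cc1ccc(C(F)(F)F)cc1)C(=O)COC(=O)c1ccc([N+](=O)[O-])o1` has not yet been measured. It differs from compound 3 in one place, with trifluoromethyl in place of fluoro on an aromatic carbon, para to a large group: trifluoromethyl in place of fluoro on an aromatic carbon. The same difference can be read as 4-fluorophenyl to 4-(trifluoromethyl)phenyl.

The nearest measured change is a step that the two limits leave unreadable from compound 2 to compound 3, with fluoro in place of methoxy on an aromatic carbon. The two other measured changes are a step that the two limits leave unreadable from compound 1 to compound 2 and a step that the two limits leave unreadable from compound 1 to compound 3. None of the three has a readable size, so they offer no measured shift to carry over.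

With compound 3 at > 100000 nM, a limit, no step beyond the scatter is expected in this assay, in either direction, and another limit is the likeliest report. The estimated change is a number no higher from compound 3 to compound 4 (the limit leaves the size open). Compound 4 is expected at about 100000 nM, with an estimated range from 45000 nM to 200000 nM.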

Compound 4, half-maximal cytotoxic concentration: 36000 nM
For compound 4 the middle estimate is 2.8-fold (0.44 log units) above the measured one, outside the stated range (below it).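

In this assay, going by these compounds alone, trifluoromethyl on an aromatic carbon, para to a large group, gives the first reading in the set that is a number and not a limit: the limit of > 100000 nM in this assay, at which 3 of the 4 values shown sit. This position therefore does respond to what it carries, and the change from fluoro is an at least 2.7-fold lower number from compound 3 to compound 4 (0.44 log units; beyond the scatter), with less compound tolerated. The same holds when trifluoromethyl replaces methoxy, an at least 2.7-fold lower number from compound 2 to compound 4 (0.44 log units; beyond the scatter), and when 4-(trifluoromethyl)phenyl replaces 2-acetoxyphenyl, an at least 2.7-fold lower number from compound 1 to compound 4 (0.44 log units; beyond the scatter), so each of the three comparisons gives only the smallest size the step can have.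

The compounds shown leave open how the reading would move with other groups on this aromatic carbon, such as a chlorine, a nitrile or an amine, and whether any of them would also bring a number and not a limit. They also leave open whether trifluoromethyl would give a similar step on the 2-acetoxyphenyl side of the series, where the acetoxy group stands on the ring in compound 1.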